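Solubility Expected to Stay High From Compound 1 to Compound 4

The compounds below may be only part of what the source reports. "The series", "measured", "known", "first", "only" and "open" are said of these compounds alone.

Compound 1 `Cc1oc(-c2c(Cl)cccc2Cl)nc1CN1CCC(C(=O)NCCCN2C[C@H](C)C[C@H](C)C2)CC1` carries a 2,6-dichlorophenyl group on its shared core. In a physicochemical assay for solubility, in phosphate buffer, measured as kinetic solubility, at pH 7.4 (a lower number here means a less soluble compound, a higher number a more soluble compound), compound 1 gives > 77 ug/mL, a limit of the measurement rather than a number; its value sits at the limit of > 77 ug/mL in this assay, at which 1 of the 3 values shown sits. Compound 2 `Cc1ccccc1-c1nc(CN2CCC(C(=O)NCCN3C[C@H](C)C[C@H](C)C3)CC2)c(C)o1` also gives a limit, > 67 ug/mL. Compound 3 `Cc1cccc(Cl)c1-c1nc(CN2CCC(C(=O)NCCCN3CCC(C)(C)CC3)CC2)c(C)o1` likewise gives a limit, > 74 ug/mL. Every value is a limit. Compound 1 cannot be placed higher or lower than the other two. Compound 4 `Cc1cccc(C)c1-c1nc(CN2CCC(C(=O)NCCCN3C[C@H](C)C[C@H](C)C3)CC2)c(C)o1` differs from compound 1 by one change: 2,6-dimethylphenyl in place of 2,6-dichlorophenyl on an aromatic carbon. Among the compounds with values here, no measured pair shows this change, so the step expected here, a step that the limit leaves unreadable from compound 1 to compound 4, is none beyond the scatter. Compound 4 is therefore estimated at 80 ug/mL, within 40 ug/mL to 160 ug/mL, most likely again reported only as a limit.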

Compound 4, solubility: 55.9 ug/mL
Compound 4: the middle estimate sits 1.4-fold (0.16 log units) above what was measured, within the range that was stated.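

In this assay, within the data shown here, compound 4 gives the first value of this set that is a number and not a limit, 55.9 ug/mL. Putting 2,6-dimethylphenyl in place of 2,6-dichlorophenyl on this aromatic carbon gives an at least 1.3-fold lower number from compound 1 to compound 4 (0.13 log units; that floor lies within the scatter), so a real drop is neither shown nor ruled out. That step is only a floor because compound 1 carries a limit: the limit of > 77 ug/mL in this assay, at which 1 of the 4 values shown sits.

Going by these compounds, how far the true gap lies beyond that floor stays open. So does what a phenyl group bearing an amine or a carboxylic acid would give at the same place.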